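Extending the nitrile of compound 3 to a cyanovinyl group

The source may hold more compounds than are shown below. What is called first, only, known or untested is meant among the compounds shown, and "the series" means these compounds.

Measured compounds:
- compound 1 `Cc1cc(C#N)cc(C)c1Oc1cc(Nc2ccc(C#N)cc2)c(N)cc1CNC1CC1`: 13 ug/mL
- compound 2 `Cc1cc(C#N)cc(C)c1Oc1cc(Nc2ccc(C#N)cc2)c(N)cc1CNCCCO`: 236 ug/mL
- compound 3 `COCc1cc(N)c(Nc2ccc(C#N)cc2)cc1Oc1c(C)cc(C#N)cc1C`: 0.07 ug/mL

In a physicochemical assay for solubility, read by HPLC, at pH 7.4 (on this read-out higher numbers stand for higher solubility and lower numbers for lower solubility), compound 3 gives the lowest of the three numbers; compound 1 lies nearest, as the step of a 190-fold lower number from compound 1 to compound 3 (2.27 log units; beyond the scatter) shows, and compound 2 lies furthest, as the step of a 3400-fold lower number from compound 2 to compound 3 (3.53 log units; beyond the scatter) shows. Compound 4 `COCc1cc(N)c(Nc2ccc(C#N)cc2)cc1Oc1c(C)cc(/C=C/C#N)cc1C` is not yet measured. It differs from compound 3 in one place: 2-cyanoethenyl in place of cyano on an aromatic carbon. The three measured steps all concern the other end of the shared core, where the saturated chain carbon bound to an aromatic carbon carries a cyclopropylamino, a (3-hydroxypropyl)amino or a methoxy group; the steps of an 18-fold higher number from compound 1 to compound 2 (1.26 log units; beyond the scatter) and a 190-fold lower number from compound 1 to compound 3 (2.27 log units; beyond the scatter) were large. For the measured compounds named here, none of them changes the group on the aromatic carbon that is altered here, so no measured step bears directly on this change. With nothing to point either way, compound 4 is expected to stay close to compound 3, an expected step of a 1.4-fold lower number from compound 3 to compound 4 (0.15 log units; within the scatter) that does not clearly leave the scatter. Compound 4 is therefore estimated at 0.05 ug/mL in this assay, within a range from 0.01 ug/mL to 0.25 ug/mL.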

Compound 4, solubility: 0.11 ug/mL
Beside the measured number, compound 4's estimate is 2.2-fold (0.34 log units) below it; measured number inside the range.
By their numbers in this assay, from the lowest: compounds 3 and 4 (each within the scatter of the next); then compound 1; then compound 2.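

Among the compounds shown, this is the only step at this aromatic carbon: in this assay, 2-cyanoethenyl in place of cyano gives a 1.6-fold higher number from compound 3 to compound 4 (0.20 log units; within the scatter), so compound 3 and compound 4 cannot be told apart on this read-out. The position thus behaves differently from the saturated chain carbon at the other end of the shared core, where a 190-fold lower number from compound 1 to compound 3 (2.27 log units; beyond the scatter) lies beyond the scatter. Nothing in the data accounts for either outcome.

From the compounds shown here alone, it remains open whether a different group on this aromatic carbon, such as an amine, a carboxylic acid or a longer chain, would leave the scatter. Going by these compounds, it is also open whether the 2-cyanoethenyl for cyano change would stay this small with cyclopropylamino, as in compound 1 at 13 ug/mL, or with (3-hydroxypropyl)amino, as in compound 2 at 236 ug/mL, on the saturated chain carbon.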